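From Methyl to Fluoro in a Mouse Antagonist Series

The compounds below may be only part of what the source reports. "The series", "measured", "known", "first", "only" and "open" are said of these compounds alone.

In a functional assay on the whole organism for antagonist activity, with Mus musculus as the target (a higher number here means that more compound is needed for the effect, a lower number that less compound is needed), compound 1 (`CCC(=O)N(c1ccc(F)cc1)C1CCCC1N(C)C`) gives 0.08 mg/kg and compound 2 (`CCC(=O)N(c1cccc(Cl)c1)C1CCCC1N(C)C`) gives 0.2 mg/kg. Compound 3 (`CCC(=O)N(c1ccc(C)c(Cl)c1)C1CCCC1N(C)C`) gives 0.6 mg/kg, the highest number of the three. Compound 4 (`CCC(=O)N(c1ccc(F)c(Cl)c1)C1CCCC1N(C)C`) has not yet been measured. It differs from compound 3 by fluoro in place of methyl on an aromatic carbon, with fluoro in place of methyl on an aromatic carbon, ortho to a chloro group and para to a large group. For the measured compounds named here, one measured step bears directly on this place: methyl in place of hydrogen on an aromatic carbon gave a 3.0-fold higher number from compound 2 to compound 3 (0.48 log units; beyond the scatter), a modest step beyond the scatter. Compound 1 carries fluoro without the chloro group and gives 0.08 mg/kg, so that compound offers no sign of a higher number with fluoro. Going by the values given here, no measured compound pairs fluoro with chloro, so the expectation remains uncertain. A downward step of similar size to the methyl step is expected in this assay, beyond the scatter. The expected change is a 3.0-fold lower number from compound 3 to compound 4 (0.48 log units; beyond the scatter). For compound 4 the estimate is 0.2 mg/kg, with an expected range of 0.07 mg/kg to 0.5 mg/kg.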

Compound 4, dose for half-maximal effect: 2 mg/kg
Compound 4: middle estimate off by 10-fold (1.00 log units), on the low side, outside the stated range (above it).
By their numbers in this assay, from the lowest: compound 1; then compound 2; then compound 3; then compound 4.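

In this assay, fluoro at this place, para to a large group and ortho to a chloro group, does not undo the methyl step but pushes further the same way, with a 3.3-fold higher number from compound 3 to compound 4 (0.52 log units; beyond the scatter). Against hydrogen at this place, fluoro also gives a higher number, with a 10-fold higher number from compound 2 to compound 4 (1.00 log units; beyond the scatter), so both methyl and fluoro raise the number here. The low number of compound 1 does not survive the addition of the chloro group, with a 25-fold higher number from compound 1 to compound 4 (1.40 log units; beyond the scatter), and nothing available explains these rises.

The compounds shown leave open how a methoxy group or a nitrile at this place would compare with methyl and fluoro. They also leave open whether fluoro at this place raises the number when the chloro group is absent.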